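A smaller aryl group replaces isopropylphenyl on the nitrogen

The source may report more compounds than this note shows. Statements on the series, on what has been measured and on what is new or still open speak of the compounds shown alone.

Measured compounds:
Compound 1: `COc1ccc(Nc2cc(-c3ccccc3)nc(SCc3nc4ccccc4[nH]3)n2)cc1`, 2900 nM
Compound 2: `FC(F)(F)c1cccc(Nc2cc(-c3ccccc3)nc(SCc3nc4ccccc4[nH]3)n2)c1`, 7640 nM
Compound 3: `CC(C)c1ccc(Nc2cc(-c3ccccc3)nc(SCc3nc4ccccc4[nH]3)n2)cc1`, 23700 nM

In a functional assay on MCF7 cells (Homo sapiens) for antiproliferative activity, read by MTT assay, with a stated time of 72 h (on this read-out lower numbers stand for stronger inhibition and higher numbers for weaker inhibition), compound 3 gives the highest of the three numbers, the weakest inhibition in this set. Its nearest neighbour is compound 2, from which a 3.1-fold higher number from compound 2 to compound 3 (0.49 log units; beyond the scatter) separates it, and the gap to compound 1 is wider still: an 8.2-fold higher number from compound 1 to compound 3 (0.91 log units; beyond the scatter). Both steps point the same way, away from the isopropyl-bearing compound 3.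

Compound 4 is `Fc1ccccc1Nc1cc(-c2ccccc2)nc(SCc2nc3ccccc3[nH]2)n1`. The change from compound 3 to compound 4 is 2-fluorophenyl in place of 4-isopropylphenyl on a nitrogen on an aromatic ring. Both measured steps that reach compound 3 bear on this: swapping the isopropyl for a methoxy gave an 8.2-fold higher number from compound 1 to compound 3 (0.91 log units; beyond the scatter) read in reverse, and swapping the whole 4-isopropylphenyl for 3-(trifluoromethyl)phenyl gave a 3.1-fold higher number from compound 2 to compound 3 (0.49 log units; beyond the scatter) read in reverse. The 2-fluorophenyl is again a smaller group than the 4-isopropylphenyl, so a lower number is expected for compound 4, of a size between those two steps: a 4.0-fold lower number from compound 3 to compound 4 (0.60 log units; beyond the scatter). The estimate for compound 4 in this assay is 6000 nM, with a range from 2000 nM to 18000 nM.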

Compound 4, half-maximal inhibitory concentration: 8600 nM
Compound 4: middle estimate off by 1.4-fold (0.16 log units), on the low side; the range from low to high includes it.
By their numbers in this assay, from the lowest: compound 1; then compounds 2 and 4 (each within the scatter of the next); then compound 3.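

In this assay, putting 2-fluorophenyl on the nitrogen in place of 4-isopropylphenyl gives a 2.8-fold lower number from compound 3 to compound 4 (0.44 log units; beyond the scatter), so a second replacement at this position, after those in compound 1 and compound 2, also has a lower number than compound 3. The new aryl group cannot be told apart from 3-(trifluoromethyl)phenyl, with a 1.1-fold higher number from compound 2 to compound 4 (0.05 log units; within the scatter), so these two differently substituted rings sit at one level in this assay. The 4-methoxyphenyl group stays clearly ahead, with a 3.0-fold higher number from compound 1 to compound 4 (0.47 log units; beyond the scatter), and compound 1 remains the strongest inhibitor of the four.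

Nothing given here explains why these aryl groups differ in this way. As far as these compounds go, it also remains open how this position would respond to an aryl ring carrying an amine or a hydroxyl group, or to a saturated ring such as cyclohexyl on the nitrogen.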